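A few compounds are considered here, and "the series" means these few. Any claim that something is new, unique, unknown or untested is made for them only; others in the source may bear on it.

In a functional assay on NCI-H460 cells (Homo sapiens) for antiproliferative activity, read by sulforhodamine B assay, with a stated time of 48 h (a lower number here means a stronger inhibitor, a higher number a weaker inhibitor), compound 1 `O=C(CCCCCCN1C(=O)/C(=N\O)c2cc(Cl)ccc21)NO` gives 850 nM, compound 2 `CO/N=C1/C(=O)N(CCCCCCC(=O)NO)c2ccc(F)cc21` gives 970 nM and compound 3 `CO/N=C1\C(=O)N(CCCCCCC(=O)NO)c2ccc([N+](=O)[O-])cc21` gives 14300 nM. Compound 2 therefore lies within the scatter of compound 1 and well beyond the scatter from compound 3. Compound 4 `CO/N=C1/C(=O)N(CCCCCCC(=O)NO)c2ccc(C)cc21`, not yet measured, carries methyl in place of fluoro on an aromatic carbon. Among the compounds with values here, no measured pair isolates this change, so the expectation is anchored on compound 2 at 970 nM. No shift beyond the scatter is expected in this assay, in either direction. The estimated step of a 1.0-fold higher number from compound 2 to compound 4 (0.01 log units; within the scatter) stays within the scatter. For compound 4 the expected value is 1000 nM, with an estimated range of 400 nM to 2500 nM.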

Compound 4, half-maximal inhibitory concentration: 1190 nM
For compound 4 the middle estimate is 1.2-fold (0.08 log units) below the measured one; measured number inside the range.
By their numbers in this assay, from the lowest: compounds 1, 2 and 4 (each within the scatter of the next); then compound 3.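

In this assay, within the data shown here, methyl in place of fluoro on an aromatic carbon gives a 1.2-fold higher number from compound 2 to compound 4 (0.09 log units; within the scatter) and is the first change isolated as a single step. For this pair, the position takes either group without a shift beyond the scatter, so the exchange of one single-heavy-atom substituent for the other leaves the antiproliferative read-out unmoved. This holds for these two groups only and sets no trend for the position.

On these data alone, whether an amine, a carboxylic acid or a methoxy group would be tolerated at this place remains open. Nothing available explains why these two groups read alike.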